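A few compounds are considered here, and "the series" means these few. Any claim that something is new, unique, unknown or untested is made for them only; others in the source may bear on it.

The compounds measured in a functional assay on the whole organism with Mus musculus as the target, in the maximal electroshock model; on this read-out lower numbers stand for an effect already at smaller amounts and higher numbers for an effect only at larger amounts of compound:

Compound 1 `CC(=O)NN(C)C(=O)NCc1ccccc1` gives > 30 mg/kg, which is a limit of the assay rather than a number.
Compound 2 `CC(=O)NN(C(=O)NCc1ccccc1)c1nccs1` gives 6.2 mg/kg.
Compound 3 `CC(=O)NN(C(=O)NCc1ccccc1)c1ccccn1` gives < 30 mg/kg, again a limit and not a number.

Compound 3 therefore stands at a limit in this assay, as the limit of < 30 mg/kg in this assay, at which 1 of the 3 values shown sits, records, so the step that the limit leaves unreadable from compound 2 to compound 3 cannot be read in size. Compound 1 sits at the opposite limit, (the limit of > 30 mg/kg in this assay, at which 1 of the 3 values shown sits), and for that reason a number no higher from compound 1 to compound 3 (the limit leaves the size open) likewise leaves the size open. Within the data shown here, the only step with a readable size is an at least 4.8-fold lower number from compound 1 to compound 2 (0.68 log units; beyond the scatter), where 1,3-thiazol-2-yl in place of methyl on an amide-type nitrogen lowers the number.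

Compound 4 `CC(=O)NN(C(=O)NCc1ccccc1)c1ncccn1` differs from compound 3 by pyrimidin-2-yl in place of pyridin-2-yl on an amide-type nitrogen. Among the measured compounds shown here, no measured step exchanges one six-membered aromatic ring for another on this amide-type nitrogen; the steps from compound 1 show only that either ring tried in place of methyl gives a number no higher, and for compound 3 only a limit exists. The step to compound 4 is hence expected to be a step that the limit leaves unreadable from compound 3 to compound 4, in no particular direction beyond the scatter. Compound 4 is estimated at 12 mg/kg, within a range from 4 mg/kg to 40 mg/kg.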

Compound 4, dose for half-maximal effect: about 30 mg/kg
Compound 4: the middle estimate sits 2.5-fold (0.40 log units) below what was measured, within the range that was stated.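

In this assay this position now has a readable step between two aromatic rings, a 4.8-fold higher number from compound 2 to compound 4 (0.68 log units; beyond the scatter), where pyrimidin-2-yl stands in place of 1,3-thiazol-2-yl on an amide-type nitrogen. The earlier compounds shown here showed a readable change only for a ring in place of methyl, whereas this step shows that the choice of ring itself can move the number beyond the scatter, so having an aromatic ring at this place does not by itself fix the value. Among these compounds, compound 4 also gives the first value that is not a limit for a six-membered aromatic ring at this place, but two of its steps cannot be read in size, as each involves a limit of the assay: a number no lower from compound 3 to compound 4 (the limit leaves the size open), and a number no higher from compound 1 to compound 4 (the limit leaves the size open).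

On these data alone, whether the second ring nitrogen of pyrimidin-2-yl matters relative to pyridin-2-yl therefore stays open. Also open, as far as these compounds go, is what a phenyl ring or an oxazol-2-yl ring would give on this amide-type nitrogen, and whether the lower number of compound 2 belongs to 1,3-thiazol-2-yl alone or extends to other five-membered aromatic rings.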